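The compounds below may be only part of what the source reports. "The series", "measured", "known", "first", "only" and "open" are said of these compounds alone.

Working notes on the series.

Compound 1, `C#CCN(Cc1ccc(OCc2cccc(F)c2)cc1)[C@@H](C)C(N)=O`, gives 7790 nM in an assay on Sf9 cells for inhibition of Amine oxidase [flavin-containing] A (Homo sapiens), with stated times of 15 min and 60 min; on this read-out higher numbers stand for weaker inhibition and lower numbers for stronger inhibition. Compound 3, `C#CCN(Cc1ccc(OCc2cccc(F)c2)cc1F)[C@@H](C)C(N)=O`, differs from compound 1 by fluoro in place of hydrogen on an aromatic carbon, and in this assay compound 3 gives 8710 nM; the step of a 1.1-fold higher number from compound 1 to compound 3 (0.05 log units; within the scatter) is small.

Compound 2, `NC(=O)[C@@H]1CCN1Cc1ccc(OCc2cccc(F)c2)cc1`, carries a different core; the difference between the two cores is not broken down here. In this assay, within the data shown here, compound 2 gives 26800 nM, which is the highest of the three numbers measured so far, and its gaps to compound 1 and to compound 3 lie beyond the scatter.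

Compound 4, `NC(=O)[C@@H]1CCN1Cc1ccc(OCc2cccc(F)c2)cc1F`, has not yet been measured. It differs from compound 2 by fluoro in place of hydrogen on an aromatic carbon. This is the same kind of change as that from compound 1 to compound 3, but not the same: in compound 3 the entering fluoro sits ortho to a large group and meta to a group of 9 heavy atoms, while in compound 4 it sits ortho to a (2-carbamoylazetidin-1-yl)methyl group and meta to a group of 9 heavy atoms.

For compound 4 the step of a 1.1-fold higher number from compound 2 to compound 4 (0.03 log units; within the scatter) is expected to stay within the scatter, because the same kind of change once gave a 1.1-fold higher number from compound 1 to compound 3 (0.05 log units; within the scatter). Compound 4 is therefore estimated at 29000 nM, with a range from 14000 nM to 60000 nM.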

Compound 4, half-maximal inhibitory concentration: 18600 nM
For compound 4 the middle estimate is 1.6-fold (0.19 log units) above the measured one; the range from low to high includes it.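

In this assay, fluoro in place of hydrogen on an aromatic carbon gives a 1.4-fold lower number from compound 2 to compound 4 (0.16 log units; within the scatter), so on the core of compound 2 this step stays within the scatter, as it did on the core of compound 1. Set side by side, the two steps do not differ by more than the scatter allows: the same change on two cores in this assay, a 1.1-fold higher number (0.05 log units; within the scatter) from compound 1 to compound 3 and a 1.4-fold lower number (0.16 log units; within the scatter) from compound 2 to compound 4, 1.6-fold (0.21 log units) apart, within the scatter of two such steps. This shows that, across these two pairs, the change carries from one core to the other with no difference that can be told apart, but it does not show that the same would hold on a third core, and with both steps this small it gives no sign that the fluoro has any effect of its own on the read-out in either core.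

Still open, as far as these compounds go, is whether a larger group at the same place, ortho to the (2-carbamoylazetidin-1-yl)methyl group, such as chloro, methoxy or a nitrile, would give a step beyond the scatter, and whether such a step would then carry between the two cores. Also open, from the compounds shown here alone, is what a carboxylic acid or an amine in place of the carbamoyl group would do on either core.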